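Methoxy to Ethoxy on Two Cores, Antiproliferative Read-out

The compounds below may be only part of what the source reports. "The series", "measured", "known", "first", "only" and "open" are said of these compounds alone.

Compound 1 `COc1cc2occ(-c3csc4ccccc34)c(=O)c2c(OC)c1OC` and compound 2 `CCOc1c(OC)cc2occ(-c3csc4ccccc34)c(=O)c2c1OC` share one core; compound 3 `COc1ccc(O)c(C(=O)/C=C/c2csc3ccccc23)c1` and compound 4 `CCOc1ccc(O)c(C(=O)/C=C/c2csc3ccccc23)c1` share another. The difference between the two cores is not broken down here. In a functional assay on KB cells (Homo sapiens) for antiproliferative activity, read by sulforhodamine B assay, with a stated time of 72 h (on this read-out higher numbers stand for weaker inhibition and lower numbers for stronger inhibition), compound 1 gives 820 nM, compound 2 gives 4000 nM and compound 3 gives 640 nM; compound 1 and compound 3 lie within the scatter of each other. The change methyl in place of hydrogen on a saturated chain carbon bound to an oxygen on an aromatic ring is measured as a 4.9-fold higher number from compound 1 to compound 2 (0.69 log units; beyond the scatter). The same change, (methyl in place of hydrogen on a saturated chain carbon bound to an oxygen on an aromatic ring), is made on the core of compound 3, where it has not yet been measured. Compound 4 is expected to show a step of about a 3.9-fold higher number from compound 3 to compound 4 (0.59 log units; beyond the scatter), resting on a 4.9-fold higher number from compound 1 to compound 2 (0.69 log units; beyond the scatter) and on compound 3 at 640 nM; with a single precedent on a different core the range is kept wide. The estimate for compound 4 is 2500 nM, between 900 nM and 7000 nM.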

Compound 4, half-maximal inhibitory concentration: 5800 nM
For compound 4 the middle estimate is 2.3-fold (0.37 log units) below the measured one, and the stated range covers the measured number.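

In this assay, methoxy to ethoxy gives a 9.1-fold higher number from compound 3 to compound 4 (0.96 log units; beyond the scatter), the same direction as on the core of compound 1. The two steps agree within the scatter, so in this series the change carries from one core to the other without a measurable difference between them: the same change on two cores in this assay, a 4.9-fold higher number (0.69 log units; beyond the scatter) from compound 1 to compound 2 and a 9.1-fold higher number (0.96 log units; beyond the scatter) from compound 3 to compound 4, 1.9-fold (0.27 log units) apart, within the scatter of two such steps. This rests on a single pair of cores, so it does not show that the step would hold on any further core, and it does not explain the size of the step.

Open, as far as these compounds go, is how a longer chain such as propoxy, or a branched one such as isopropoxy, would read on the same oxygen. Also open, from the compounds shown here alone, is how a free hydroxyl or a chain ending in an amine would read there.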